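Carbamate to cyclic thioimidate on the sugar arm

This account rests on a few compounds, and the source may have more. Where it says the series, first, only, none or still open, it means among the compounds named here.

In an assay on DDT1 cells (Cricetulus griseus) for binding affinity to adenosine receptor A1 (Homo sapiens), read by radioligand binding (a lower number here means a stronger inhibitor, a higher number a weaker inhibitor), compound 3 `CCCCNC(=O)OC[C@H]1OC(n2cnc3c(NC4CCOC4)ncnc32)[C@H](O)[C@@H]1O` gives 1410 nM, the highest number of the three measured compounds. Among the measured compounds shown here, compound 1 `C/N=C(\S)OC[C@H]1OC(n2cnc3c(NC4CCOC4)nc(Cl)nc32)[C@H](O)[C@@H]1O` gives 71 nM and compound 2 `CC/N=C(\S)OC[C@H]1OC(n2cnc3c(NC4CCOC4)nc(Cl)nc32)[C@H](O)[C@@H]1O` gives 55 nM; the step of a 1.3-fold lower number from compound 1 to compound 2 (0.11 log units; within the scatter) is the only one-place change measured, and it shows no shift beyond the scatter. Compound 4 `O[C@@H]1[C@@H](CO/C(S)=N/C2CCC2)OC(n2cnc3c(NC4CCOC4)ncnc32)[C@@H]1O` carries a group of 7 heavy atoms (5 carbon, 1 nitrogen, 1 sulfur; one four-membered non-aromatic ring of carbon only) in place of a group of 7 heavy atoms (5 carbon, 1 nitrogen, 1 oxygen; no ring), on an oxygen on a saturated carbon. For the measured compounds named here, no measured step covers this particular swap, and compound 1 and compound 2 also differ from compound 3 in their core, so their lower numbers cannot be read as a direct guide. A move towards the range of compound 1 and compound 2 seems plausible but uncertain. Compound 4 is expected at 250 nM, between 60 nM and 1000 nM. The expected step is a 5.6-fold lower number from compound 3 to compound 4 (0.75 log units; beyond the scatter).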

Compound 4, inhibition constant: 148 nM
Estimate against measurement, compound 4: 1.7-fold (0.23 log units) above, within the range that was stated.
By their numbers in this assay, from the lowest: compounds 2 and 1 (each within the scatter of the next); then compound 4; then compound 3.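

With the shared core held constant, this assay shows that this position responds to the change: putting a sulfur-bearing group with a four-membered ring of carbon only in place of butylcarbamoyl, on an oxygen on a saturated carbon, gives a 9.5-fold lower number from compound 3 to compound 4 (0.98 log units; beyond the scatter). Compounds 1 and 2 could not show this, as their core differs from that of compound 3. No measurement here accounts for the step.

From the compounds shown here alone, the swap alters the ring, the sulfur and the oxygen-for-sulfur exchange together, so which of these matters stays open. A cyclopentyl ring or a longer chain in place of the four-membered ring could begin to separate them.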